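This account rests on a few compounds, and the source may have more. Where it says the series, first, only, none or still open, it means among the compounds named here.

Measured compounds:
compound 1 `CNC(=O)c1cc(Oc2ccc(NC(=O)c3nn(-c4cccc(F)c4)c(=O)cc3C)cc2F)ccn1`, 10200 nM
compound 2 `Cc1cc(=O)n(-c2cccc(F)c2)nc1C(=O)Nc1ccc(Oc2ncnc3ccsc23)cc1`, 10200 nM
compound 3 `Cc1cc(=O)n(-c2ccccc2OC(F)(F)F)nc1C(=O)Nc1ccc(Oc2ncnc3ccsc23)c(F)c1`, 15700 nM

In a functional assay on HepG2 cells (Homo sapiens) for cytotoxicity, read by MTT assay, with a stated time of 72 h (a higher number here means a weaker inhibitor, a lower number a stronger inhibitor), compound 3 gives the highest number of the three, yet compound 1 and compound 2 both sit within the scatter of it, so no order among them can be read. Compound 4 `Cc1cc(=O)n(-c2cccc(F)c2)nc1C(=O)Nc1ccc(Oc2ncnc3ccsc23)c(F)c1` differs from compound 3 by 3-fluorophenyl in place of 2-(trifluoromethoxy)phenyl on an aromatic nitrogen. Within the data shown here, no step between measured compounds is known in this assay, and compound 2, which carries the same 3-fluorophenyl on the same aromatic nitrogen, gives a number within the scatter of compound 3. The step from compound 3 to compound 4 is therefore expected to stay within the scatter, in no clear direction, as a 1.4-fold lower number from compound 3 to compound 4 (0.15 log units; within the scatter). Compound 4 is expected at 11000 nM, with a range from 5000 nM to 25000 nM.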

Compound 4, half-maximal inhibitory concentration: 7810 nM
Beside the measured number, compound 4's estimate is 1.4-fold (0.15 log units) above it; measured number inside the range.
By their numbers in this assay, from the lowest: compounds 4, 1, 2 and 3 (each within the scatter of the next).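

In this assay, 3-fluorophenyl in place of 2-(trifluoromethoxy)phenyl on the aromatic nitrogen gives a 2.0-fold lower number from compound 3 to compound 4 (0.30 log units; within the scatter), so even this exchange of a larger group for a smaller one does not move the number beyond the scatter. Fluoro in place of hydrogen on an aromatic carbon gives a 1.3-fold lower number from compound 2 to compound 4 (0.12 log units; within the scatter), and the exchange of the group on the oxygen gives a 1.3-fold lower number from compound 1 to compound 4 (0.12 log units; within the scatter), both also within the scatter. No measured explanation bears on these steps.

From the compounds shown here alone, whether an amine or a carboxylic acid in place of the aryl group on that aromatic nitrogen would shift the number beyond the scatter remains open.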